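This account rests on a few compounds, and the source may have more. Where it says the series, first, only, none or still open, it means among the compounds named here.

Compound 1 `CC(C)Oc1ccc(/N=c2\[nH]c(=O)n(C[C@@H](C)C(=O)O)c(=O)n2Cc2ccc(Cl)cc2)cc1Cl`: 108%
Compound 2 `C[C@@H](Cn1c(=O)[nH]/c(=N\c2ccc(Oc3ccc(F)cn3)cc2)n(Cc2ccc(Cl)cc2)c1=O)C(=O)O`: 82.4%

In an ADME assay on the whole organism (Rattus norvegicus) for pharmacokinetics, using cassette dosing, at a dose of 1 mg/kg by the oral route (a higher number here means that a larger share of the oral dose reaches the circulation, a lower number that a smaller share of the oral dose reaches the circulation), compound 2 gives 82.4%, the lower of the two numbers, and compound 1 gives 108%, a gap beyond the scatter. Compound 3 `C[C@@H](Cn1c(=O)[nH]/c(=N\c2ccc(OC3CCC3)cc2)n(Cc2ccc(Cl)cc2)c1=O)C(=O)O` differs from compound 2 on an oxygen on an aromatic ring: cyclobutyl in place of 5-fluoropyridin-2-yl on an oxygen on an aromatic ring. Among the compounds with values here, no measured step covers this change, so the expectation starts from compound 2 at 82.4% and is for no step beyond the scatter. The expected change is a number 3.6 percentage points higher from compound 2 to compound 3 (within the scatter). For compound 3 the estimated value is 86%, with an expected range of 60% to 110%.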

Compound 3, oral bioavailability: 54.3%
Compound 3: the middle estimate sits 31.7 percentage points above what was measured; the measured number lies below the stated range.
By their numbers in this assay, from the lowest: compound 3; then compound 2; then compound 1.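

In this assay, the group on an oxygen on an aromatic ring matters in this series: cyclobutyl in place of 5-fluoropyridin-2-yl gives a number 28.1 percentage points lower from compound 2 to compound 3 (beyond the scatter), with the rest of the structure unchanged. Within the data shown here, the high numbers of the earlier compounds therefore do not carry over to every group at this place. Nothing at hand accounts for the drop. Still open, going by these compounds, is whether the difference follows the aromatic ring, its nitrogen or its fluorine. Also open, on these data alone, is how a plain phenyl or a cyclohexyl on the same oxygen would read.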